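Ether length and potency at the histamine H1 receptor

The source may hold more compounds than are shown below. What is called first, only, known or untested is meant among the compounds shown, and "the series" means these compounds.

Compound 1 `CN1CCN(c2nc3ccccc3n2CCO)CC1`: 410 nM
Compound 2 `CCCOCCn1c(N2CCN(C)CC2)nc2ccccc21`: 20 nM
Compound 3 `CCCC(C)Cn1c(N2CCN(C)CC2)nc2ccccc21`: 500 nM

In a functional assay on ileum for inhibition of histamine H1 receptor (Cavia porcellus) (a lower number here means a stronger inhibitor, a higher number a weaker inhibitor), compound 3 gives the highest number of the three; compound 1 sits within the scatter of it, while compound 2 is far stronger, as a 25-fold higher number from compound 2 to compound 3 (1.40 log units; beyond the scatter) shows. Compound 4 `COCCn1c(N2CCN(C)CC2)nc2ccccc21` carries the change (methoxymethyl in place of 1-methylbutyl on a saturated chain carbon bound to an aromatic nitrogen). Among the compounds with values here, two measured steps bear on it: a 25-fold higher number from compound 2 to compound 3 (1.40 log units; beyond the scatter) and a 21-fold lower number from compound 1 to compound 2 (1.31 log units; beyond the scatter), both large. The 2-methoxyethyl chain of compound 4 lies between the hydroxyethyl of compound 1 and the propoxyethyl of compound 2, so compound 4 is expected to improve on compound 3 by a clear step, a 6.3-fold lower number from compound 3 to compound 4 (0.80 log units; beyond the scatter), though not to the full extent seen for compound 2. Compound 4 is therefore estimated at 80 nM, with a range from 25 nM to 300 nM.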

Compound 4, half-maximal inhibitory concentration: 13 nM
Compound 4: middle estimate off by 6.2-fold (0.79 log units), on the high side; measured number outside the range, below it.
By their numbers in this assay, from the lowest: compounds 4 and 2 (each within the scatter of the next); then compounds 1 and 3 (each within the scatter of the next).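

In this assay, 2-methoxyethyl in place of 2-methylpentyl brings a large gain (a 38-fold lower number from compound 3 to compound 4 (1.59 log units; beyond the scatter)), and this gain does not depend on the longer propoxy end of compound 2, since the shorter methoxy end stays within the scatter of it (a 1.5-fold lower number from compound 2 to compound 4 (0.19 log units; within the scatter)). Methyl on the oxygen of compound 1 is already enough for a large step (a 32-fold lower number from compound 1 to compound 4 (1.50 log units; beyond the scatter)), so at this place methyl and propyl on the oxygen cannot be told apart. The compounds shown leave open whether an amine in place of the ether oxygen, or a butoxy end, would hold this potency. No other measurement here bears on these steps.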